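From Fluoro to Chloro on a Shared Core

A few compounds are considered here, and "the series" means these few. Any claim that something is new, unique, unknown or untested is made for them only; others in the source may bear on it.

Three closely related compounds have been tested in a functional assay on DU-145 cells (Homo sapiens) for antiproliferative activity, read by MTT assay, with a stated time of 72 h; a higher number here means a weaker inhibitor, a lower number a stronger inhibitor. Compound 1 `O=C(CNc1ccc(Cl)cc1Cl)N[C@H]1CCOC1=O`, compound 2 `O=C(CNc1ccccc1)N[C@H]1CCOC1=O` and compound 3 `O=C(CNc1ccc(F)cc1)N[C@H]1CCOC1=O` share the same core and differ only in what sits on the aromatic ring. In this assay compound 1 gives > 64000 nM, which is a limit of the assay and not a number. Compound 2 gives > 64000 nM, again a limit. Compound 3 gives > 64000 nM, also a limit. Compound 3 therefore stands exactly where every measured compound stands, at the limit, with no number read for any of them (the limit of > 64000 nM in this assay, at which 3 of the 3 values shown sit). Among the measured compounds shown here, the one step from compound 2 to compound 3, fluoro in place of hydrogen on an aromatic carbon, is a step that the two limits leave unreadable from compound 2 to compound 3.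

Compound 4 `O=C(CNc1ccc(Cl)cc1)N[C@H]1CCOC1=O` differs from compound 3 by chloro in place of fluoro on an aromatic carbon. For the measured compounds named here, the only measured step that bears on this change is unreadable, so no size and no direction can be drawn from it, and none of compounds 1, 2 and 3 supplies a number to build on. The expected step from compound 3 to compound 4 is a step that the limit leaves unreadable from compound 3 to compound 4, meaning no change that the assay could show. Compound 4 is accordingly estimated at 100000 nM, in a range from 40000 nM to 300000 nM, and is most likely to be reported once more only as a limit.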

Compound 4, half-maximal inhibitory concentration: > 64000 nM
Compound 4: a limit, no number; the forecaster's own chance of this, stated with the estimate: 85%; the middle value does not contradict the limit.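

In this assay compound 4 gives > 64000 nM, which is a limit of the assay and not a number. No step from compound 1, compound 2 or compound 3 to compound 4 can be read, as all four compounds stop at the same limit: the limit of > 64000 nM in this assay, at which 4 of the 4 values shown sit.

The compounds shown leave open whether any of these changes on the aromatic ring alters antiproliferative activity at all.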